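A few compounds are considered here, and "the series" means these few. Any claim that something is new, unique, unknown or untested is made for them only; others in the source may bear on it.

Measured in a functional assay on HL-60 cells (Homo sapiens) for inhibition, read by MTT assay, with a stated time of 48 h, tested at 10 uM; a higher number here means more inhibition of growth at the concentration tested, a lower number less inhibition of growth:
- compound 1 `Cc1cc(=O)c2c(O)c(CN3CCCC3)c(O)c([C@H]3CCN(C)C[C@H]3O)c2o1`: 38%
- compound 2 `Cc1cc(=O)c2c(O)c(CN3CCC(Cc4ccccc4)CC3)c(O)c([C@H]3CCN(C)C[C@H]3O)c2o1`: 28%
- compound 3 `Cc1cc(=O)c2c(O)c(CN3CCC(c4ccccc4)CC3)c(O)c([C@H]3CCN(C)C[C@H]3O)c2o1`: 26%

In this assay, compound 1 gives 38% and compound 3 gives 26%. The gap between these two compounds lies beyond the scatter, with compound 1 the higher. Compound 2 at 28% lies within the scatter of compound 1.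

Compound 4 `CCOC(=O)N1CCN(Cc2c(O)c([C@H]3CCN(C)C[C@H]3O)c3oc(C)cc(=O)c3c2O)CC1` carries 4-(ethoxycarbonyl)piperazin-1-yl in place of pyrrolidin-1-yl on a saturated chain carbon bound to an aromatic carbon.

Among the measured compounds shown here, no measured step covers this exchange. The only one available, a number 2 percentage points lower from compound 2 to compound 3 (within the scatter), is a different change, phenyl in place of benzyl on a saturated ring carbon, and it stays within the scatter, so it offers only weak guidance. For the measured compounds named here, the values themselves give no sign of a rise, and compound 3 at 26% is the one value clear of compound 1. A modest fall, near the edge of the scatter, is therefore expected: a number 10 percentage points lower from compound 1 to compound 4 (within the scatter). For compound 4 the estimated value is 28%, with an expected range from 14% to 42%.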

Compound 4, percent growth inhibition at one concentration: 16%
Compound 4: the middle estimate sits 12 percentage points above what was measured, and the stated range covers the measured number.
By their numbers in this assay, from the lowest: compounds 4, 3, 2 and 1 (each within the scatter of the next, the first and the last beyond it).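

In this assay the exchange of pyrrolidin-1-yl for 4-(ethoxycarbonyl)piperazin-1-yl on a saturated chain carbon bound to an aromatic carbon gives a number 22 percentage points lower from compound 1 to compound 4 (beyond the scatter) and is the first listed step to pass beyond the scatter. Among the compounds shown here, the only earlier step, phenyl in place of benzyl on a saturated ring carbon, stayed within the scatter, so this result is the first to show that a single exchange on the shared core can clearly lower growth inhibition at the concentration tested.

The entering group differs from pyrrolidin-1-yl in ring size, in its second ring nitrogen and in its ethoxycarbonyl group, and the compounds shown do not separate these changes. As far as these compounds go, whether a plain piperazin-1-yl or a piperidin-1-yl at this place would stand nearer compound 1 or compound 4 remains open. No measurement available here accounts for the fall.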